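Swapping chloro for hydroxy on the hydrazone aryl ring

The compounds below may be only part of what the source reports. "The series", "measured", "known", "first", "only" and "open" are said of these compounds alone.

Measured so far:
compound 1, `O=C(COc1cccc2ccccc12)N/N=C/c1ccc(O)cc1`, 20 ug/mL
compound 2, `O=C(COc1cccc2ccccc12)N/N=C/c1cccc(O)c1`, 100 ug/mL
compound 3, `O=C(COc1cccc2ccccc12)N/N=C/c1ccccc1Cl`, 100 ug/mL

In an ADME assay on HEL cells (Homo sapiens) for cytotoxicity (a lower number here means that less compound is tolerated, a higher number that more compound is tolerated), compound 3 stands level with compound 2 at the digits printed, and the two share the highest number of the three; compound 1 sits furthest away, with a 5.0-fold higher number from compound 1 to compound 3 (0.70 log units; beyond the scatter). Compound 4, `O=C(COc1cccc2ccccc12)N/N=C/c1ccccc1O`, carries the change (hydroxy in place of chloro on an aromatic carbon). Within the data shown here, no measured step exchanges chloro for hydroxy at one and the same position. Among the measured compounds shown here, the steps that bear on it only show that where a hydroxy sits matters: a 5.0-fold higher number from compound 1 to compound 2 (0.70 log units; beyond the scatter), whereas no change at the digits printed from compound 2 to compound 3 (within the scatter). For the measured compounds named here, a hydroxy ortho to a large group has no precedent here, so a modest change in either direction in this assay is possible. Compound 4 is therefore expected to give about 70 ug/mL, between 25 ug/mL and 200 ug/mL, which means an estimated 1.4-fold lower number from compound 3 to compound 4 (0.15 log units; within the scatter).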

Compound 4, minimum cytotoxic concentration in the HEL assay: 20 ug/mL
Compound 4: middle estimate off by 3.5-fold (0.54 log units), on the high side; the whole stated range lies above it.
By their numbers in the HEL assay, from the lowest: compounds 1 and 4 (each within the scatter of the next); then compounds 2 and 3 (each within the scatter of the next).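

In the HEL assay the exchange of chloro for hydroxy ortho to a large group is not silent: there is a 5.0-fold lower number from compound 3 to compound 4 (0.70 log units; beyond the scatter). Among the hydroxy compounds, 2-hydroxyphenyl stands with 4-hydroxyphenyl, with no change at the digits printed from compound 1 to compound 4 (within the scatter), while 3-hydroxyphenyl stays apart, with a 5.0-fold lower number from compound 2 to compound 4 (0.70 log units; beyond the scatter). In a physicochemical assay for lipophilicity, measured as octanol-water partition (on this read-out lower numbers stand for lower lipophilicity and higher numbers for higher lipophilicity), compound 3 gives 4.54 and compound 4 gives 3.73, so the same exchange also lowers lipophilicity: the measured partition coefficient of compound 3, 4.54, and of compound 4, 3.73, a number 0.81 log units lower (beyond the scatter). From the compounds shown here alone, whether a methoxy or an amine on this carbon would stand with chloro or with hydroxy in the HEL assay stays open.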